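This account rests on a few compounds, and the source may have more. Where it says the series, first, only, none or still open, it means among the compounds named here.

In a functional assay on PLC-PRF-5 cells (Homo sapiens) for inhibition, read by MTT assay, with a stated time of 72 h (on this read-out lower numbers stand for stronger inhibition and higher numbers for weaker inhibition), compound 1 `Nc1ncnc2c1c(-c1cnc3[nH]ccc3c1)nn2CCCCCC(=O)NO` gives > 150000 nM as a limit. Compound 2 `Nc1ncnc2c1c(-c1cnc3[nH]ccc3c1)nn2CCCCCCC(=O)NO` gives > 50000 nM as a limit too, so it has no number to stand on. Compound 3 `Nc1nc2cc(-c3nn(CCCCCCC(=O)NO)c4ncnc(N)c34)ccc2o1` keeps the chain and the shared core of compound 2 and carries this change: a group of 10 heavy atoms (7 carbon, 2 nitrogen, 1 oxygen; one five-membered aromatic ring with 2 hetero atoms, one six-membered aromatic ring of carbon only) in place of a group of 9 heavy atoms (7 carbon, 2 nitrogen; one five-membered aromatic ring with 1 hetero atom, one six-membered aromatic ring with 1 hetero atom), on an aromatic carbon in the same place. For the measured compounds named here, the one measured step is a step that the two limits leave unreadable from compound 1 to compound 2 and it lies in the chain, so no size carries over to this aromatic carbon. Compound 2 stands at > 50000 nM as a limit, and only a move toward stronger inhibition can be read against it. The expected change is an at least 16-fold lower number from compound 2 to compound 3 (1.22 log units; beyond the scatter) in this assay with wide uncertainty. The value expected for compound 3 is 3000 nM with an estimated range from 200 nM to 60000 nM in this read-out.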

Compound 3, half-maximal inhibitory concentration: > 50000 nM
Compound 3: no number, only a limit; the forecaster's own chance of this, stated with the estimate: 25%; middle value at least 16-fold (1.22 log units) from the limit.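

For the compounds shown here, compound 2 and compound 3 both stand only as limits in this assay, so no step between them can be read. The compounds shown leave open whether the 2-amino-1,3-benzoxazol-5-yl group changes inhibition at all, as none has a number.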